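Swapping cyclopropyl for piperidin-3-yl on the shared core

A few compounds are considered here, and "the series" means these few. Any claim that something is new, unique, unknown or untested is made for them only; others in the source may bear on it.

In a functional assay on cells (Homo sapiens), read by thymidine incorporation (on this read-out higher numbers stand for weaker inhibition and lower numbers for stronger inhibition), compound 2 (`Brc1cnn2c(NCc3cccnc3)cc(C3CC3)nc12`) gives 1500 nM and sits level with compound 1 (`Cc1cc(NCc2cccnc2)n2ncc(Br)c2n1`) at 1800 nM on this scale. Cyclopropyl in place of methyl produced a 1.2-fold lower number from compound 1 to compound 2 (0.08 log units; within the scatter) and is the only measured step at this carbon. Compound 3 (`Clc1ccccc1-c1cc(NCc2cccnc2)n2ncc(Br)c2n1`) carries a different group there and shows a lower number of 500 nM; 500 nM (2 entries) in both of its entries. Compound 4 (`Brc1cnn2c(NCc3cccnc3)cc(C3CCCNC3)nc12`), still unmeasured, has piperidin-3-yl in place of cyclopropyl on an aromatic carbon. Going by the values given here, with only that small step and the lower value of compound 3 (500 nM; 500 nM (2 entries)) as guides, a modest move towards stronger inhibition is expected in this assay (a 2.1-fold lower number from compound 2 to compound 4 (0.33 log units; beyond the scatter)). For compound 4 the estimated value is 700 nM (range 170 nM to 2800 nM).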

Compound 4, half-maximal inhibitory concentration: 60 nM
For compound 4 the middle estimate is 12-fold (1.07 log units) above the measured one; the measured number lies below the stated range.
By their numbers in this assay, from the lowest: compound 4; then compounds 2 and 1 (each within the scatter of the next).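

In this assay, this carbon proved far more responsive than the swap of methyl for cyclopropyl had suggested: piperidin-3-yl gives a 25-fold lower number from compound 2 to compound 4 (1.40 log units; beyond the scatter) and a 30-fold lower number from compound 1 to compound 4 (1.48 log units; beyond the scatter). The change replaces a three-membered carbon ring with a six-membered ring containing a nitrogen, so the larger ring and the added hetero atom arrive together, and these results cannot separate them. A cyclohexyl group, the all-carbon six-membered ring, would be needed to tell these two changes apart. No other data here bear on why the number falls so far.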